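The compounds below may be only part of what the source reports. "The series", "measured", "known", "first", "only" and "open" are said of these compounds alone.

Going by the values given here, in a functional assay on OVCAR-3 cells (Homo sapiens) for inhibition, read by MTT assay, with a stated time of 24 h (a lower number here means a stronger inhibitor, a higher number a weaker inhibitor), two compounds sharing one core have numbers so far. Among the compounds with values here, compound 1 `CC1(C)[C@H]2CC[C@]1(C)N(Cc1cn(-c3cccc(F)c3)nn1)C(=O)C2` gives 430 nM, and compound 2 `CC1(C)[C@H]2CC[C@]1(C)N(Cc1cn(-c3ccccc3Br)nn1)C(=O)C2` gives 140 nM, the lowest number so far, which makes it the stronger inhibitor of the pair. Within the data shown here, the only measured step is a 3.1-fold lower number from compound 1 to compound 2 (0.49 log units; beyond the scatter). It came with 2-bromophenyl in place of 3-fluorophenyl on an aromatic nitrogen, and it is modest but beyond the usual scatter.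

Compound 3 `CC1(C)[C@H]2CC[C@]1(C)N(Cc1cn(-c3ccc(C#N)cc3)nn1)C(=O)C2` keeps the shared core and has no number yet. It carries 4-cyanophenyl in place of 2-bromophenyl on an aromatic nitrogen of a five-membered aromatic ring with 3 nitrogen: 4-cyanophenyl in place of 2-bromophenyl on an aromatic nitrogen. Among the measured compounds shown here, the change falls at the same place as the measured step, so that step is the only guide to its size, and a single step cannot show how this new group will behave. Compound 2 sits at the low end with 140 nM, so a modest rise in the number seems more likely than a further fall. The expected change is a 2.1-fold higher number from compound 2 to compound 3 (0.33 log units; beyond the scatter). The estimate for compound 3 is 300 nM, with an expected range from 100 nM to 900 nM.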

Compound 3, half-maximal inhibitory concentration: 380 nM
For compound 3 the middle estimate is 1.3-fold (0.10 log units) below the measured one; measured number inside the range.
By their numbers in this assay, from the lowest: compound 2; then compounds 3 and 1 (each within the scatter of the next).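

In this assay, a 2.7-fold higher number from compound 2 to compound 3 (0.43 log units; beyond the scatter), so the 4-cyanophenyl group, which brings a nitrile and a hydrogen-bond acceptor to this aromatic nitrogen, does not keep the stronger inhibition of the 2-bromophenyl group. Beside this, a 1.1-fold lower number from compound 1 to compound 3 (0.05 log units; within the scatter), so the 4-cyanophenyl and 3-fluorophenyl groups cannot be told apart here, while compound 2 now stands apart from two different replacements rather than one and is the strongest inhibitor of the three. Nothing available explains why the 2-bromophenyl group gives the lowest number.

The compounds shown leave open whether the lower number of compound 2 belongs to the bromine itself or to where it sits on the phenyl ring, a question that a plain phenyl, a 4-bromophenyl and a 2-cyanophenyl group could help to separate. Also open, going by these compounds, is how this position would respond to a phenyl ring carrying an amine or a carboxylic acid, or to an alkyl chain in place of the phenyl ring.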